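Adding one methyl to a compound at the assay limit

The source may hold more compounds than are shown below. What is called first, only, known or untested is meant among the compounds shown, and "the series" means these compounds.

In an ADME assay on THP-1 cells (Homo sapiens) for cytotoxicity, read by flow cytometry and propidium iodide staining, with a stated time of 72 h (on this read-out lower numbers stand for stronger inhibition and higher numbers for weaker inhibition), compound 1 (`Cc1ccc(S(=O)(=O)Cc2ncn(C)c2[N+](=O)[O-])cc1`) reads > 846000 nM as a limit, not a number. Compound 2 (`Cc1nc(CS(=O)(=O)c2ccccc2)c([N+](=O)[O-])n1C`) reads > 846000 nM and this too is a limit. Compound 2 thus stands at the limit of > 846000 nM in this assay, at which 2 of the 2 values shown sit, for now. Compound 3 (`Cc1ccc(S(=O)(=O)Cc2nc(C)n(C)c2[N+](=O)[O-])cc1`) differs from compound 2 in one place (methyl in place of hydrogen on an aromatic carbon): methyl in place of hydrogen on an aromatic carbon, turning phenyl to 4-methylphenyl. For the measured compounds named here, no measured pair shows this change, so no step beyond the usual scatter is expected in this assay here. The estimated step is an at least 1.0-fold lower number from compound 2 to compound 3 (0.01 log units; that floor lies within the scatter) in size. Compound 3 is estimated at 810000 nM with an expected range of 300000 nM to 1000000 nM in this measurement.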

Compound 3, half-maximal inhibitory concentration: 242000 nM
Compound 3: middle estimate off by 3.3-fold (0.52 log units), on the high side; the whole stated range lies above it.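

In this assay, for the compounds shown here, the methyl on the six-membered ring gives the first step that can be read (an at least 3.4-fold lower number from compound 2 to compound 3 (0.54 log units; beyond the scatter)). A methyl on another aromatic carbon of the core gives a second step (an at least 3.4-fold lower number from compound 1 to compound 3 (0.54 log units; beyond the scatter)), so compound 1 and compound 2 each lack one of these methyls and stay at a limit, while compound 3 carries both and gives a measured value. From the compounds shown here alone, both steps start from a limit, so their full size stays unknown: the limit of > 846000 nM in this assay, at which 2 of the 3 values shown sit. Going by these compounds, whether a longer chain or an amine in place of the 4-methyl would lower the number further remains open.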